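The source may report more compounds than this note shows. Statements on the series, on what has been measured and on what is new or still open speak of the compounds shown alone.

Compound 1 (`Cc1ccc(-c2cn(C[C@H](O)[C@H]3OC(=O)C(OCc4ccccc4)=C3OCc3ccccc3)nn2)cc1`) gives 8690 nM
Compound 2 (`C[Si](C)(C)c1cn(C[C@H](O)[C@H]2OC(=O)C(OCc3ccccc3)=C2OCc2ccccc2)nn1`) gives 19200 nM

These values come from a functional assay on A549 cells (Homo sapiens) for antiproliferative activity, read by MTT assay, with a stated time of 72 h (a higher number here means a weaker inhibitor, a lower number a stronger inhibitor), and compound 2, at 19200 nM, holds the higher of the two numbers, which makes it the weaker of the pair. The next compound, compound 3 (`O=C1O[C@H]([C@@H](O)Cn2cc(CCO)nn2)C(OCc2ccccc2)=C1OCc1ccccc1`), differs from it by one exchange: a group of 3 heavy atoms (2 carbon, 1 oxygen; no ring) in place of a group of 4 heavy atoms (3 carbon, 1 silicon; no ring), on an aromatic carbon. The entering group is 2-hydroxyethyl, and the rest of the structure stays the same. Within the data shown here, only one measured step bears on this place, a 2.2-fold higher number from compound 1 to compound 2 (0.34 log units; beyond the scatter), which is modest. Among the measured compounds shown here, that step swaps a group with a ring for one without, and no measured step brings in a hydrogen-bond donor, so it is only a rough guide. A similarly modest rise or no real change is therefore expected in this assay. The expected change is a 1.5-fold higher number from compound 2 to compound 3 (0.16 log units; within the scatter) as estimated here. Compound 3 is estimated at 28000 nM within an expected range from 11000 nM to 70000 nM in this assay.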

Compound 3, half-maximal inhibitory concentration: > 100000 nM
Compound 3 was reported as a limit (the forecaster's own chance of this, stated with the estimate: 20%); middle value at least 3.5-fold (0.55 log units) away from the limit.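

In this assay compound 3 is reported only as a limit, not as a number: the limit of > 100000 nM in this assay, at which 1 of the 3 values shown sits.

The steps to it are therefore lower bounds: 2-hydroxyethyl in place of the silicon-bearing group gives an at least 5.2-fold higher number from compound 2 to compound 3 (0.71 log units; beyond the scatter), and 2-hydroxyethyl in place of 4-methylphenyl gives an at least 11-fold higher number from compound 1 to compound 3 (1.06 log units; beyond the scatter). Among these compounds, the earlier compounds showed only a modest difference at this aromatic carbon, between two groups with no hydrogen-bond donor, whereas 2-hydroxyethyl, the only group of the three with a hydrogen-bond donor, shows that this position can cost far more.

The compounds shown do not separate the hydroxyl from the chain that carries it, and a plain ethyl, a longer chain ending in methoxy or a chain ending in an amine would bear on that. From the compounds shown here alone, the true value of compound 3 also stays unknown.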